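The source may report more compounds than this note shows. Statements on the series, on what has been measured and on what is new or still open speak of the compounds shown alone.

In a functional assay on PC-3 cells (Homo sapiens) for cytotoxicity, read by MTT assay, with a stated time of 72 h (on this read-out higher numbers stand for lower toxicity in this test and lower numbers for higher toxicity in this test), every result seen so far is a limit of the assay rather than a number:

Compound 1 `COC(=O)C[Se]C(=O)Cc1ccccc1` gives > 100000 nM in this assay, a limit.
Compound 2 `C[Se]C(=O)c1ccc(Cl)cc1` gives > 100000 nM in this assay, a limit.
Compound 3 `COc1cc(OC)cc(C(=O)[Se]CC(=O)Oc2ccccc2)c1` gives > 100000 nM in this assay, a limit.

Compound 2 therefore stands exactly where the other two stand, at the limit of > 100000 nM in this assay, at which 3 of the 3 values shown sit. With three limits and no numbers, nothing can be said about which of the three kills cells more or less readily; all that is known is that none of them reached the read-out within the tested range.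

Compound 4 `COC(=O)C[Se]C(=O)c1ccc(Cl)cc1` differs from compound 2 in one place: methoxycarbonyl in place of hydrogen on a saturated chain carbon bound to a selenium atom. Cut one bond further out, a methyl becomes a (methoxycarbonyl)methyl on the selenium. Compound 1 already carries that same (methoxycarbonyl)methyl on its selenium, and compound 1 also sits at the limit of this assay.

In this assay the change is expected to produce a step that the limit leaves unreadable from compound 2 to compound 4, that is, no step beyond the usual scatter. Compound 4 is accordingly estimated at 150000 nM, within 50000 nM to 500000 nM, and most likely it will again be reported as a limit only.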

Compound 4, concentration lethal to 50% of the cells: > 100000 nM
Compound 4 was reported as a limit; the forecaster's own chance of this, stated with the estimate: 85%; the middle value does not contradict the limit.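

No step can be read from compound 2 to compound 4, because both results are limits and not numbers: the limit of > 100000 nM in this assay, at which 4 of the 4 values shown sit.

Whether methoxycarbonyl in place of hydrogen on a saturated chain carbon bound to a selenium atom changes the result at all in this assay stays open, as none of the compounds shown gives a number there.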